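The source may report more compounds than this note shows. Statements on the series, on what has been measured and on what is new or still open speak of the compounds shown alone.

In an ADME assay on cells (Hepatocyte, Homo sapiens) for metabolic stability, with a stated time of 30 min (a higher number here means that more of the compound is left, a lower number that less of the compound is left), the three measured compounds gave:
compound 1, `O=C(OC1CCC(CN2CCN(c3cc(=O)c4cc(C(F)(F)F)cc([N+](=O)[O-])c4s3)CC2)CC1)c1ccco1`, 1%;
compound 2, `O=C(OC1CCC(CN2CCN(c3cc(=O)c4cc(C(F)(F)F)cc([N+](=O)[O-])c4s3)CC2)CC1)c1ccc(F)cc1`, 3%;
compound 3, `O=C(OC1CCC(CN2CCN(c3cc(=O)c4cc(C(F)(F)F)cc([N+](=O)[O-])c4s3)CC2)CC1)c1cccs1`, 2.2%.

Compound 3 stands second highest of these three numbers, but every gap among them lies within the usual scatter, so no order can be read from them. Compound 4, `O=C(OC1CCC(CN2CCN(c3cc(=O)c4cc(C(F)(F)F)cc([N+](=O)[O-])c4s3)CC2)CC1)c1ccccc1`, differs from compound 3 in one place: phenyl in place of thiophen-2-yl on a carbonyl carbon. The steps already measured at this carbonyl carbon are a number 2 percentage points higher from compound 1 to compound 2 (within the scatter), a number 1.2 percentage points higher from compound 1 to compound 3 (within the scatter) and a number 0.8 percentage points lower from compound 2 to compound 3 (within the scatter), all within the scatter. Swapping the aromatic ring on the carbonyl carbon has therefore not moved this assay beyond its scatter, and for compound 4 no step beyond the scatter is expected, a number 0.3 percentage points higher from compound 3 to compound 4 (within the scatter). The estimate for compound 4 is 2.5%, with a range from 0.5% to 8%.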

Compound 4, percent of the compound remaining: 56.4%
For compound 4 the middle estimate is 53.9 percentage points below the measured one; measured number outside the range, above it.
By their numbers in this assay, from the lowest: compounds 1, 3 and 2 (each within the scatter of the next); then compound 4.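

Within this assay the ring on this carbonyl carbon can matter after all: phenyl in place of thiophen-2-yl gives a number 54.2 percentage points higher from compound 3 to compound 4 (beyond the scatter) and phenyl in place of furan-2-yl gives a number 55.4 percentage points higher from compound 1 to compound 4 (beyond the scatter). Even a single fluoro counts, as hydrogen in its place on the aromatic carbon gives a number 53.4 percentage points higher from compound 2 to compound 4 (beyond the scatter). No measurement at hand explains these large jumps.

As far as these compounds go, whether a chloro, a methyl or an amine in place of that hydrogen would keep the high number stays open. So does the outcome for a pyridine ring in place of phenyl.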